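Ring Closure of the Ether Side Chain: Compound 4 Estimated

The source may report more compounds than this note shows. Statements on the series, on what has been measured and on what is new or still open speak of the compounds shown alone.

Compound 1, `Nc1ccc2cccc(OCCC(F)(F)F)c2n1`: 722 nM
Compound 2, `CCC(C)COc1cccc2ccc(N)nc12`: 36 nM
Compound 3, `CCCCOc1cccc2ccc(N)nc12`: 789 nM

In an assay on cells with melanin-concentrating hormone receptor 1 (Homo sapiens) as the target, read by radioligand binding (on this read-out lower numbers stand for stronger inhibition and higher numbers for weaker inhibition), compound 3 gives the highest number of the three, though its gap to compound 1 is within the scatter; the step of a 22-fold higher number from compound 2 to compound 3 (1.34 log units; beyond the scatter) is the one large difference that sets it apart. Compound 4, `Nc1ccc2cccc(OC3CCCCC3)c2n1`, differs from compound 3 in one place: cyclohexyl in place of butyl on an oxygen on an aromatic ring. The steps bearing on this change are a 22-fold higher number from compound 2 to compound 3 (1.34 log units; beyond the scatter) and a 20-fold lower number from compound 1 to compound 2 (1.30 log units; beyond the scatter), both large, and both show that a bulkier group on the oxygen brings a markedly lower number. Compound 4 is therefore expected to give a lower number than compound 3, with a step of a 7.9-fold lower number from compound 3 to compound 4 (0.90 log units; beyond the scatter). The estimate for compound 4 is 100 nM, within a range from 20 nM to 500 nM.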

Compound 4, half-maximal inhibitory concentration: 361 nM
Beside the measured number, compound 4's estimate is 3.6-fold (0.56 log units) below it, and the stated range covers the measured number.
By their numbers in this assay, from the lowest: compound 2; then compounds 4, 1 and 3 (each within the scatter of the next, the first and the last beyond it).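

In this assay, cyclohexyl on the oxygen brings only a 2.2-fold lower number from compound 3 to compound 4 (0.34 log units; beyond the scatter), and 2-methylbutyl keeps a clear lead, with a 10-fold higher number from compound 2 to compound 4 (1.00 log units; beyond the scatter). The large gain seen with 2-methylbutyl therefore does not carry over in full to cyclohexyl, so a larger group on the oxygen does not by itself reach the number of compound 2. Against 3,3,3-trifluoropropyl, cyclohexyl stays within the scatter, with a 2.0-fold lower number from compound 1 to compound 4 (0.30 log units; within the scatter). No measurement here explains these differences. From the compounds shown here alone, whether cyclopentyl or an isobutyl chain would come closer to 2-methylbutyl remains open.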